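Notes toward compound 4

The source may hold more compounds than are shown below. What is called first, only, known or untested is meant among the compounds shown, and "the series" means these compounds.

Compound 3 `COc1ccc(C2CC(=NOC(=O)c3ccc(O)cc3)CC(c3ccc(OC)cc3)N2C)cc1` holds the lowest number of the three measured compounds in a functional assay, with a stated time of 30 min (on this read-out higher numbers stand for weaker inhibition and lower numbers for stronger inhibition), at 25000 nM. Compound 1 `COc1ccc(C2CC(=NO)CC(c3ccc(OC)cc3)N2C)cc1` gives 380000 nM in this assay, and compound 2 `COc1ccc(C2CC(=NOC(=O)c3ccccc3)CC(c3ccc(OC)cc3)N2C)cc1` gives 375000 nM; the step of a 1.0-fold lower number from compound 1 to compound 2 (0.01 log units; within the scatter) lies within the scatter, whereas a 15-fold lower number from compound 1 to compound 3 (1.18 log units; beyond the scatter) and a 15-fold lower number from compound 2 to compound 3 (1.18 log units; beyond the scatter) are both well beyond it. Compound 4 `COc1ccc(C2CC(=NOC(=O)c3ccc(OC)cc3OC)CC(c3ccc(OC)cc3)N2C)cc1` is not yet measured. The change from compound 3 is 2,4-dimethoxyphenyl in place of 4-hydroxyphenyl on a carbonyl carbon: the hydroxy that set compound 3 apart from compound 2 is gone, and two methoxy groups enter in its place. The step bearing most directly on this is a 15-fold lower number from compound 2 to compound 3 (1.18 log units; beyond the scatter), which shows what the hydroxy alone contributed; a 1.0-fold lower number from compound 1 to compound 2 (0.01 log units; within the scatter) shows that the bare benzoyl on the oxygen added nothing. Going by the values given here, no measured step tells what a methoxy on this ring does, so the loss of the hydroxy is weighed most, and a number between compound 2 and compound 3, nearer compound 2, is expected for compound 4. The expected step is a 6.0-fold higher number from compound 3 to compound 4 (0.78 log units; beyond the scatter), towards weaker inhibition. Compound 4 is estimated at 150000 nM in this assay, within the range 40000 nM to 500000 nM.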

Compound 4, half-maximal inhibitory concentration: 80000 nM
The estimate for compound 4 lay 1.9-fold (0.27 log units) above the measured number; the range from low to high includes it.
By their numbers in this assay, from the lowest: compound 3; then compound 4; then compounds 2 and 1 (each within the scatter of the next).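

In this assay, substitution on this ring can pay off without a hydroxy: 2,4-dimethoxyphenyl in place of phenyl on a carbonyl carbon gives a 4.7-fold lower number from compound 2 to compound 4 (0.67 log units; beyond the scatter), and (2,4-dimethoxyphenyl)carbonyl in place of hydrogen on the oxygen gives a 4.8-fold lower number from compound 1 to compound 4 (0.68 log units; beyond the scatter), whereas the bare benzoyl made no difference beyond the scatter. The hydroxy is therefore not the only substituent here that moves the number, yet 4-hydroxyphenyl keeps the lead, with 2,4-dimethoxyphenyl in its place giving a 3.2-fold higher number from compound 3 to compound 4 (0.51 log units; beyond the scatter). Nothing available on these compounds accounts for any of these steps.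

The two methoxy groups entered together, so how much of the gain belongs to each one, and whether a single methoxy would be enough, stays unresolved. Also open, as far as these compounds go, is whether the hydroxy can be matched or bettered on this ring by another group, such as an amine or a carboxylic acid, and whether a hydroxy and a methoxy on the same ring would add up.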